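This account rests on a few compounds, and the source may have more. Where it says the series, first, only, none or still open, it means among the compounds named here.

Of the compounds shown here, three built on one shared core have been measured in an in vitro assay on HEK385-7 cells for displacement of a labelled ligand from prostaglandin D2 receptor 2 (Homo sapiens); on this read-out lower numbers stand for stronger inhibition and higher numbers for weaker inhibition. Compound 1 `O=C(O)Cc1sc(C(c2ccc(F)cc2)c2ccc(F)cc2)nc1-c1cn[nH]c1` gives 16 nM. Compound 2 `O=C(O)Cc1sc(C(c2ccc(F)cc2)c2ccc(F)cc2)nc1-c1ccncc1` gives 5.3 nM, and compound 3 `O=C(O)Cc1sc(C(c2ccc(F)cc2)c2ccc(F)cc2)nc1-c1ccnc(F)c1` gives 0.48 nM, the lowest number of the three, with the steps of a 33-fold lower number from compound 1 to compound 3 (1.52 log units; beyond the scatter) and an 11-fold lower number from compound 2 to compound 3 (1.04 log units; beyond the scatter) both beyond the scatter. Compound 4 `O=C(O)Cc1sc(C(c2ccc(F)cc2)c2ccc(F)cc2)nc1-c1ccnc(Cl)c1` has not yet been measured. It differs from compound 3 by chloro in place of fluoro on an aromatic carbon, next to the ring nitrogen. Going by the values given here, no measured step exchanges one halogen for another at this place. Among the compounds with values here, the only step there is an 11-fold lower number from compound 2 to compound 3 (1.04 log units; beyond the scatter), which put fluoro where hydrogen stood. An exchange of one halogen for another is expected to move the number less than that, in an uncertain direction. Compound 4 is therefore expected to give 0.6 nM, between 0.2 nM and 2 nM, a step of a 1.3-fold higher number from compound 3 to compound 4 (0.10 log units; within the scatter).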

Compound 4, half-maximal inhibitory concentration: 3.1 nM
Compound 4: middle estimate off by 5.2-fold (0.71 log units), on the low side, and the stated range ends below it.
By their numbers in this assay, from the lowest: compound 3; then compounds 4 and 2 (each within the scatter of the next); then compound 1.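

Chloro does not share the gain that fluoro brought at this place on the pyridine ring, since exchanging one halogen for the other reverses most of it (a 6.5-fold higher number from compound 3 to compound 4 (0.81 log units; beyond the scatter)), and chloro in place of hydrogen stays within the scatter (a 1.7-fold lower number from compound 2 to compound 4 (0.23 log units; within the scatter)). The 2-chloropyridin-4-yl group still keeps a modest edge over 1H-pyrazol-4-yl (a 5.2-fold lower number from compound 1 to compound 4 (0.71 log units; beyond the scatter)). Nothing available accounts for the difference between the two halogens. Going by these compounds, how bromo, methyl or methoxy at this place would compare with fluoro remains open.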